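This account rests on a few compounds, and the source may have more. Where it says the series, first, only, none or still open, it means among the compounds named here.

Compound 1 `COC(=O)c1ccc(O)c(NC(=O)C(C)(C)Oc2ccc(C(C)(C)CC(C)(C)C)cc2)c1` — 3000 nM
Compound 2 `COC(=O)c1cccc(NC(=O)COc2ccc(C(C)(C)CC(C)(C)C)cc2)c1` — 6650 nM
Compound 3 `C#CCN1CCN(C(=O)COc2ccc(C(C)(C)CC(C)(C)C)cc2)CC1` — > 40000 nM

Of the compounds shown here, three have so far been tested in an assay for inhibition of malate dehydrogenase, cytoplasmic (Homo sapiens), with a stated time of 30 min; on this read-out lower numbers stand for stronger inhibition and higher numbers for weaker inhibition. Compound 1 gives 3000 nM, and compound 2 gives 6650 nM. Compound 3 is different in kind: for it the assay returns only a limit, > 40000 nM, and no number is known. Among the compounds with values here, it is therefore the single compound that sits at the limit of > 40000 nM in this assay, at which 1 of the 3 values shown sits, while the two anilides return measurable figures.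

The next compound in the series is compound 4 `CC(C)(C)CC(C)(C)c1ccc(OCC(=O)N2CCN(Cc3ccc(C(F)(F)F)cc3)CC2)cc1`. It keeps the core of compound 3 and differs in one place: 4-(trifluoromethyl)phenyl in place of ethynyl on a saturated chain carbon bound to an amine nitrogen in a ring. Within the data shown here, no measured step of this kind is available among the three compounds, so the size of the change can only be estimated. Compound 3 offers no number to build on, only the limit, so any expectation for compound 4 begins from that edge of the assay. The step of an at least 1.6-fold lower number from compound 3 to compound 4 (0.20 log units; that floor lies within the scatter) is expected to run toward stronger inhibition, modestly, with a real chance that compound 4 also stops at the limit. Compound 4 is thus estimated at 25000 nM, with a range from 8000 nM to 60000 nM.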

Compound 4, half-maximal inhibitory concentration: 4740 nM
Compound 4: middle estimate off by 5.3-fold (0.72 log units), on the high side; the measured number lies below the stated range.
By their numbers in this assay, from the lowest: compounds 1, 4 and 2 (each within the scatter of the next, the first and the last beyond it). At a limit, above all of these: compound 3.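

In this assay, the place on a saturated chain carbon bound to an amine nitrogen in a ring turns out to govern whether the series gives a measurable figure at all. Within the data shown here, putting 4-(trifluoromethyl)phenyl in place of ethynyl gives an at least 8.4-fold lower number from compound 3 to compound 4 (0.92 log units; beyond the scatter), a step beyond the scatter and the first measured step at any position, and it shows that this place tolerates a much larger group, with 10 heavy atoms entering where 2 leave. The true size of the step remains unknown because compound 3 carries a limit and not a number, so the printed step is only a floor: the limit of > 40000 nM in this assay, at which 1 of the 4 values shown sits.

The compounds shown leave open whether the step belongs to the aromatic ring itself or to the trifluoromethyl group on it, a question that a plain benzyl or a 4-methoxybenzyl at this place would separate. Also open, from the compounds shown here alone, is whether an aromatic ring is needed at all, or whether a saturated group such as cyclohexylmethyl or a longer alkyl chain would carry a similar step.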